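This account rests on a few compounds, and the source may have more. Where it says the series, first, only, none or still open, it means among the compounds named here.

- Compound 1 `CC1=NN(C(=O)C(F)(F)F)C(c2ccccc2O)C1`: 2890 nM
- Compound 2 `CC1=NN(C(=O)CBr)C(c2ccccc2O)C1`: 3650 nM
- Compound 3 `COc1ccc(C(=O)N2N=C(C)CC2c2ccccc2O)cc1`: 38500 nM

In a functional assay on MGC-803 cells (Homo sapiens) for antiproliferative activity, read by MTT assay, with a stated time of 48 h (on this read-out higher numbers stand for an effect only at larger amounts of compound and lower numbers for an effect already at smaller amounts), compound 3 gives the highest of the three numbers, 38500 nM, and so needs the largest amount to act. Compound 1 and compound 2 both sit well below it, and within the scatter of each other.

Compound 4 `CC1=NN(C(=O)c2ccc(F)cc2)C(c2ccccc2O)C1` keeps compound 3 unchanged except for one swap: fluoro in place of methoxy on an aromatic carbon, para to a large group (fluoro in place of methoxy on an aromatic carbon).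

Within the data shown here, no measured pair shows this swap. Among the measured compounds shown here, the only measured step, a 1.3-fold higher number from compound 1 to compound 2 (0.10 log units; within the scatter), is a change on a carbonyl carbon, not on an aromatic ring, so it offers only weak guidance. It does show one exchange of groups that leaves the number within the scatter. A similarly small effect is therefore expected here, with no clear direction and a wide margin of uncertainty.

The expected outcome is a 1.5-fold lower number from compound 3 to compound 4 (0.19 log units; within the scatter).

For compound 4 the estimated value is 25000 nM, with an expected range from 7000 nM to 70000 nM.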

Compound 4, half-maximal effective concentration: 35400 nM
Compound 4: the middle estimate sits 1.4-fold (0.15 log units) below what was measured; low and high end bracket the measured number.
By their numbers in this assay, from the lowest: compounds 1 and 2 (each within the scatter of the next); then compounds 4 and 3 (each within the scatter of the next).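

In this assay, fluoro in place of methoxy on an aromatic carbon, para to a large group, leaves the number within the scatter (a 1.1-fold lower number from compound 3 to compound 4 (0.04 log units; within the scatter)). The group on the carbonyl carbon matters far more in this set: 4-fluorophenyl in place of bromomethyl gives a step beyond the scatter (a 9.7-fold higher number from compound 2 to compound 4 (0.99 log units; beyond the scatter)), and 4-fluorophenyl in place of trifluoromethyl gives another (a 12-fold higher number from compound 1 to compound 4 (1.09 log units; beyond the scatter)). No measurement shown here offers an explanation for either finding.

From the compounds shown here alone, only methoxy and fluoro are seen on that aromatic carbon, so it remains open whether an amine or a carboxylic acid there would shift the number. Also open, going by these compounds, is whether a longer chain on the carbonyl carbon, such as butyl, would give a number nearer compound 1 or compound 4.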